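Working notes: one stereocentre redrawn in the series

The source may report more compounds than this note shows. Statements on the series, on what has been measured and on what is new or still open speak of the compounds shown alone.

Measured so far in an ADME assay for permeability; on this read-out higher numbers stand for higher permeability and lower numbers for lower permeability
- compound 1 (`CNC(=O)c1cc(C(=O)NC2CC2)cn([C@H](C)c2ccccc2)c1=O`) gives 160 nm/s
- compound 2 (`CCNC(=O)c1cc(C(=O)NC)nn1[C@@H](C)c1ccccc1`) gives 435 nm/s

Compound 1 stands at 160 nm/s as the lower of the two numbers, and compound 2 lies beyond the scatter from it. Compound 3 (`CNC(=O)c1cc(C(=O)NC2CC2)cn([C@@H](C)c2ccccc2)c1=O`) is not yet measured, and its change from compound 1 reads as follows (the two compounds have the same atoms and bonds and differ only in configuration as drawn: 1 of 1 stereo elements differ; a stereocentre at a saturated chain carbon is drawn R in compound 1 and S in compound 3). Going by the values given here, no measured pair shows a step of this kind, so the expectation rests on compound 1 at 160 nm/s alone, with no step beyond the scatter in this assay and no direction expected. The expected step is a 1.0-fold higher number from compound 1 to compound 3 (0.01 log units; within the scatter) and stays within the scatter. For compound 3 the estimate is 165 nm/s with an expected range from 85 nm/s to 320 nm/s in this measurement.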

Compound 3, apparent permeability in the ADME assay: 16 nm/s
Compound 3: middle estimate off by 10-fold (1.01 log units), on the high side, and the stated range ends above it.
By their numbers in the ADME assay, from the lowest: compound 3; then compound 1; then compound 2.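

Going by these compounds alone, in the ADME assay, compound 1 gives 160 nm/s and compound 3 gives 16 nm/s; redrawing the stereocentre at the saturated chain carbon from R to S gives a 10-fold lower number from compound 1 to compound 3 (1.00 log units; beyond the scatter), so this position is sensitive to configuration alone, which no earlier pair could show. The step can be traced to that stereocentre: the fact that compounds 1 and 3 differ only in the configuration as drawn. In a physicochemical assay for lipophilicity (a lower number here means a more polar compound, a higher number a more lipophilic compound), compound 1 gives 3.5 and compound 3 gives 3.3; the same change gives a number 0.20 log units lower from compound 1 to compound 3 (within the scatter).

What lies behind the step in the ADME assay remains open. Also open, on these data alone, is whether a step of this size would persist with a longer chain in place of the methyl on the stereocentre, or on the core of compound 2.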